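Swapping tert-butyl for allyl on a fused core

The source may report more compounds than this note shows. Statements on the series, on what has been measured and on what is new or still open speak of the compounds shown alone.

Of the compounds shown here, three that share a fused core have been measured in a functional assay on aorta with Alpha-1D adrenergic receptor (Rattus norvegicus) as the target; a higher number here means that more compound is needed for the effect, a lower number that less compound is needed. Compound 1, `Cn1nc(Cc2cccc3ccccc23)c2ccccc2c1=O`, gives 14000 nM. Compound 2, `O=c1c2ccccc2c(Cc2ccc(Cl)cc2)nn1-c1ccc([N+](=O)[O-])cc1`, gives 29000 nM. Compound 3, `COc1ccc(Cc2nn(C(C)(C)C)c(=O)c3ccccc23)cc1OC`, gives 10000 nM. Compound 3 gives the lowest of the three numbers, yet compound 1 stands within the usual scatter of it, so those two cannot be placed in order; only compound 2 stands clearly apart, beyond the scatter. Going by the values given here, none of these three differs from another in a single place, so no measured step between them exists.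

Compound 4, `C=CCn1nc(Cc2ccc(OC)c(OC)c2)c2ccccc2c1=O`, has not yet been measured. Its difference from compound 3 is allyl in place of tert-butyl on an aromatic nitrogen — in words, allyl in place of tert-butyl on an aromatic nitrogen. Among the compounds with values here, both groups are short carbon chains, and no measured pair here shows what such an exchange does, so the outlook rests on compound 3 alone. The step from compound 3 to compound 4 in this assay is expected to be no change at the digits printed from compound 3 to compound 4 (within the scatter), which means no change beyond the scatter in either direction. Compound 4 is therefore estimated at 10000 nM, with a range from 3500 nM to 30000 nM.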

Compound 4, half-maximal effective concentration: 9800 nM
Beside the measured number, compound 4's estimate is 1.0-fold (0.01 log units) above it; the measured number falls inside the stated range.
By their numbers in this assay, from the lowest: compounds 4, 3 and 1 (each within the scatter of the next); then compound 2.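

Going by these compounds alone, this is the first single-place exchange that can be read in the set: in this assay, allyl in place of tert-butyl on the aromatic nitrogen gives a 1.0-fold lower number from compound 3 to compound 4 (0.01 log units; within the scatter), a step within the scatter. The exchange takes away one carbon and brings in a double bond outside aromatic rings, yet with the rest of compound 3 held fixed, the number does not shift beyond the scatter, so these two groups cannot be told apart at this nitrogen in this assay. No measurement available here accounts for the two groups reading alike.

As far as these compounds go, whether that holds for a longer chain, an amine or a carboxylic acid on the same nitrogen stays open, as does whether the same exchange would read alike on a compound with a different group on the shared core. Compound 1 and compound 2 carry other groups on this nitrogen, but they also differ from compound 3 and compound 4 in a second place, so they cannot settle either question.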